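This account rests on a few compounds, and the source may have more. Where it says the series, first, only, none or still open, it means among the compounds named here.

Measured compounds:
compound 1, `Nc1ccccc1NC(=O)c1ccc(CSC(=S)N2CCc3cc(Cl)ccc32)cc1`: in a functional assay on HeLa cells (Homo sapiens) for antiproliferative activity, read by CCK-8 assay, with a stated time of 72 h, tested at 8 uM (on this read-out lower numbers stand for a weaker effect and higher numbers for a stronger effect at the one concentration tested), compound 1 gives 65.1%
compound 2, `Nc1ccccc1NC(=O)c1ccc(CSC(=S)N2CCc3cc([N+](=O)[O-])ccc32)cc1`: in this assay compound 2 gives 43.6%

Compound 2 stands lowest of the two numbers shown; its nearest neighbour is compound 1, which lies higher by a margin beyond the scatter. Within the data shown here, the single measured step, a number 21.5 percentage points lower from compound 1 to compound 2 (beyond the scatter), consists of nitro in place of chloro on an aromatic carbon and is a modest change that is nonetheless beyond the scatter.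

Compound 3, `COC(=O)c1ccc2c(c1)CCN2C(=S)SCc1ccc(C(=O)Nc2ccccc2N)cc1`, differs from compound 2 by methoxycarbonyl in place of nitro on an aromatic carbon. Among the measured compounds shown here, no measured step involves methoxycarbonyl, so the only information bearing on this change is the step from compound 1 to compound 2, which shows that exchanging the group on that aromatic carbon can shift the read-out by a modest amount in either direction. With nothing tying methoxycarbonyl to either the chloro or the nitro outcome, the expected step is small and uncertain in sign, most likely within the scatter. Compound 3 is therefore estimated at 50%, with a range from 30% to 70%. This estimate corresponds to an expected step of a number 6.4 percentage points higher from compound 2 to compound 3 (within the scatter).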

Compound 3, a percentage reported as inhibition, at one concentration (the size of the read-out at that concentration, not a potency): 60.1%
Estimate against measurement, compound 3: 10.1 percentage points below, within the range that was stated.
By their numbers in this assay, from the lowest: compound 2; then compounds 3 and 1 (each within the scatter of the next).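

In this assay, methoxycarbonyl in place of nitro on this aromatic carbon gives a number 16.5 percentage points higher from compound 2 to compound 3 (beyond the scatter) and so shows that the low number of compound 2 does not extend to every group exchanged here, even though nitro and methoxycarbonyl share the same count of hydrogen-bond acceptors. Methoxycarbonyl in place of chloro gives a number 5 percentage points lower from compound 1 to compound 3 (within the scatter) and leaves compound 1 and compound 3 indistinguishable, so that among these three compounds only compound 2 stands apart, as the weakest, with its steps to both others beyond the scatter. No measurement bearing on the reason for this separation is available.

As far as these compounds go, whether an amine, a carboxylic acid or a longer ester such as ethoxycarbonyl on this aromatic carbon would stay level with compound 1 and compound 3 or fall toward compound 2 remains open, as does the effect of a plain hydrogen there. Since each compound is described by its read-out at one concentration only, the compounds shown also leave open whether compound 1 and compound 3 would still give a similar effect at other concentrations.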